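This account rests on a few compounds, and the source may have more. Where it says the series, first, only, none or still open, it means among the compounds named here.

Measured compounds:
compound 1 `COc1cccc(CNCCCNc2ccnc3cc(Cc4ccccc4)ccc23)c1O`, 5720 nM in an ADME assay on HepG2 cells (Homo sapiens) for cytotoxicity, read by luminescence, CellTiter-Glo and ATP content, with a stated time of 72 h; on this read-out lower numbers stand for an effect already at smaller amounts and higher numbers for an effect only at larger amounts of compound
compound 2 `COc1ccc(F)cc1CNCCCNc1ccnc2cc(Cc3ccccc3)ccc12`, 7990 nM
compound 3 `CC(C)(C)c1ccc(-c2ccc3c(NCCCNCc4ccco4)ccnc3c2)cc1`, 3150 nM

Compound 1 stands second highest of the three numbers; its nearest neighbour is compound 2, with a 1.4-fold higher number from compound 1 to compound 2 (0.15 log units; within the scatter), and compound 3 gives the lowest number, still within the usual scatter of compound 1. Compound 4 `COc1ccc(-c2ccc3c(NCCCNCc4cccc(OC)c4O)ccnc3c2)cc1` differs from compound 1 by 4-methoxyphenyl in place of benzyl on an aromatic carbon. Among the measured compounds shown here, no measured step changes a group at this position; the only aromatic change on record, a 1.4-fold higher number from compound 1 to compound 2 (0.15 log units; within the scatter), sits on the saturated chain carbon and stays within the scatter. Compound 3, which also carries an aryl group at this aromatic carbon, gives a number within the scatter of compound 1. No step beyond the scatter is therefore expected, a 1.3-fold lower number from compound 1 to compound 4 (0.10 log units; within the scatter). Compound 4 is expected at 4500 nM, range 2000 nM to 10000 nM.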

Compound 4, half-maximal effective concentration: 1600 nM
Compound 4: the middle estimate sits 2.8-fold (0.45 log units) above what was measured; the whole stated range lies above it.
By their numbers in this assay, from the lowest: compounds 4, 3, 1 and 2 (each within the scatter of the next, the first and the last beyond it).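

Among the compounds shown here, on this aromatic carbon, 4-methoxyphenyl in place of benzyl gives a 3.6-fold lower number from compound 1 to compound 4 (0.55 log units; beyond the scatter) in this assay and is the first single change to pass the scatter. For the compounds shown here, the read-out therefore responds to the group held at this position, whereas the one earlier step, on a saturated chain carbon, stayed within the scatter. Nothing available explains this step.

Open, on these data alone, is whether the step follows from the methoxy group or from the aryl group replacing benzyl. Plain phenyl at this carbon would separate the two, and 4-aminophenyl would test another substituent on that ring.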